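Nitro for chloro in a well-tolerated series

This account rests on a few compounds, and the source may have more. Where it says the series, first, only, none or still open, it means among the compounds named here.

In an ADME assay on MT4 cells (Homo sapiens) for cytotoxicity, read by MTT assay (a lower number here means that less compound is tolerated, a higher number that more compound is tolerated), compound 1 `CC(=O)CSc1nc(Cc2c(F)cccc2F)cc(=O)[nH]1` gives > 81000 nM, which is a limit. Compound 2 `O=C(CSc1nc(Cc2c(F)cccc2F)cc(=O)[nH]1)c1ccccc1` gives > 67000 nM, also a limit. Compound 3 `O=C(CSc1nc(Cc2c(F)cccc2F)cc(=O)[nH]1)c1ccc(Cl)cc1` stands at > 61000 nM, again only a limit. Compound 4 `O=C(CSc1nc(Cc2c(F)cccc2F)cc(=O)[nH]1)c1ccc([N+](=O)[O-])cc1` carries nitro in place of chloro on an aromatic carbon. The closest measured change, chloro in place of hydrogen on an aromatic carbon, is a step that the two limits leave unreadable from compound 2 to compound 3, so in this assay no step beyond the scatter is expected for compound 4. The changes on the carbonyl carbon, a step that the two limits leave unreadable from compound 1 to compound 2 and a step that the two limits leave unreadable from compound 1 to compound 3, add no size either. The expected outcome is an at least 1.1-fold lower number from compound 3 to compound 4 (0.04 log units; that floor lies within the scatter). Compound 4 is estimated at 55000 nM, within an expected range of 20000 nM to 90000 nM.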

Compound 4, half-maximal cytotoxic concentration: 22000 nM
Compound 4: middle estimate off by 2.5-fold (0.40 log units), on the high side; the range from low to high includes it.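

In this assay, among the compounds shown here, the change from 4-chlorophenyl to 4-nitrophenyl gives the first readable step, an at least 2.7-fold lower number from compound 3 to compound 4 (0.44 log units; beyond the scatter), whereas the steps among the earlier compounds cannot be read. Nitro also separates from hydrogen at this aromatic carbon, an at least 3.0-fold lower number from compound 2 to compound 4 (0.48 log units; beyond the scatter), and the 4-nitrophenyl group separates from methyl on the carbonyl carbon, an at least 3.6-fold lower number from compound 1 to compound 4 (0.56 log units; beyond the scatter). The true size of the step from chloro is open, since it gives only a floor and rests on a limit: the limit of > 61000 nM in this assay, at which 1 of the 4 values shown sits.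

The compounds shown leave open whether this drop belongs to nitro alone. They also leave open what an amine or a carboxylic acid would give at the same carbon.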